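Trading a bromobutoxy chain for allyloxy on the isoflavone

The source may hold more compounds than are shown below. What is called first, only, known or untested is meant among the compounds shown, and "the series" means these compounds.

Compound 2 `O=c1c(-c2ccc(O)cc2)coc2cc(OCCCCBr)ccc12` stands second highest of the three numbers in a functional assay on mitochondria (Cricetulus griseus) for inhibition of Monoamine oxidase (Homo sapiens), tested at 0.3 uM (on this read-out higher numbers stand for a stronger effect at the one concentration tested and lower numbers for a weaker effect), with 19.2%; compound 1 `O=c1c(-c2ccc(O)cc2)coc2cc(CC3OC(CO)C(O)C(O)C3O)ccc12` gives 0%, and compound 3 `O=c1c(-c2ccc(O)cc2)coc2cc(OCCCBr)ccc12` gives 51.1%. Compound 4 `C=CCOc1ccc2c(=O)c(-c3ccc(O)cc3)coc2c1` differs from compound 2 by vinyl in place of 3-bromopropyl on a saturated chain carbon bound to an oxygen on an aromatic ring. For the measured compounds named here, only one measured step bears on it, and only in part: a number 31.9 percentage points higher from compound 2 to compound 3 (beyond the scatter), where the chain also grew shorter. Going by the values given here, no measured pair shows what the loss of bromine does, so the direction for compound 4 is uncertain, though a gain beyond the scatter seems somewhat more likely than a loss. Compound 4 is therefore expected to give 30%, within 5% to 60%, which would mean an estimated step of a number 10.8 percentage points higher from compound 2 to compound 4 (beyond the scatter).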

Compound 4, a percentage reported as inhibition, at one concentration (the size of the read-out at that concentration, not a potency): 37.9%
Compound 4: the middle estimate sits 7.9 percentage points below what was measured; low and high end bracket the measured number.
By their numbers in this assay, from the lowest: compound 1; then compound 2; then compound 4; then compound 3.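

Bromine proves unnecessary for a measurable effect on this saturated chain carbon bound to an oxygen on an aromatic ring: allyloxy in place of 4-bromobutoxy gives a gain (a number 18.7 percentage points higher from compound 2 to compound 4 (beyond the scatter)). That gain does not reach the level of the shorter bromo chain (a number 13.2 percentage points lower from compound 3 to compound 4 (beyond the scatter)), so the allyl chain falls between the two bromo chains. No evidence at hand explains either step. Still open, from the compounds shown here alone, is how far bromine and chain length each set these numbers, and what an amine or a carboxylic acid in place of the allyl group would give.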